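Methylated azoles on the shared core

The source may hold more compounds than are shown below. What is called first, only, known or untested is meant among the compounds shown, and "the series" means these compounds.

Compound 1 `c1ccc(-c2nc[nH]n2)c(NCC2=NCCN2)c1` gives 0.794 nM in an in vitro functional assay on cells (Fibroblast) for agonist activity at Alpha-1A adrenergic receptor (Homo sapiens); on this read-out lower numbers stand for an effect already at smaller amounts and higher numbers for an effect only at larger amounts of compound. Compound 2 `Cc1n[nH]c(-c2ccccc2NCC2=NCCN2)n1` gives 794 nM and compound 3 `Cn1cc(-c2ccccc2NCC2=NCCN2)cn1` gives 398 nM, so compound 3 stands second highest of the three numbers, close to compound 2 and far from compound 1. The two large steps, a 1000-fold higher number from compound 1 to compound 2 (3.00 log units; beyond the scatter) and a 500-fold higher number from compound 1 to compound 3 (2.70 log units; beyond the scatter), separate the unmethylated azole from the azoles that carry a methyl group, whereas the step of a 2.0-fold lower number from compound 2 to compound 3 (0.30 log units; within the scatter) between the two methylated azoles is within the scatter. Compound 4 `Cn1ccnc1-c1ccccc1NCC1=NCCN1` carries 1-methyl-1H-imidazol-2-yl in place of 1-methyl-1H-pyrazol-4-yl on an aromatic carbon. It remains a methylated azole, and on the evidence of compound 2 and compound 3 no change beyond the scatter is expected. The expected step is accordingly a 1.0-fold higher number from compound 3 to compound 4 (0.00 log units; within the scatter). Compound 4 is estimated at 400 nM, within 80 nM to 2500 nM.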

Compound 4, half-maximal effective concentration: 6.31 nM
For compound 4 the middle estimate is 63-fold (1.80 log units) above the measured one, and the stated range ends above it.
By their numbers in this assay, from the lowest: compound 1; then compound 4; then compounds 3 and 2 (each within the scatter of the next).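

In this assay, the presence of a methyl group does not by itself set the level at this position: the groups of compound 3 and compound 4 match in atoms and counts, yet exchanging one for the other gives a large change (a 63-fold lower number from compound 3 to compound 4 (1.80 log units; beyond the scatter)). The methylated azoles therefore no longer sit together (a 130-fold lower number from compound 2 to compound 4 (2.10 log units; beyond the scatter)), although compound 1 keeps the lowest number (a 7.9-fold higher number from compound 1 to compound 4 (0.90 log units; beyond the scatter)). Nothing available accounts for this difference between the two isomeric groups.

Open, from the compounds shown here alone, is whether an ethyl group in place of the methyl on the 1-methyl-1H-imidazol-2-yl keeps this level, and whether the unmethylated 1H-imidazol-2-yl reaches the level of compound 1.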